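A few compounds are considered here, and "the series" means these few. Any claim that something is new, unique, unknown or untested is made for them only; others in the source may bear on it.

Measured so far:
Compound 1 `Oc1cccc(-c2ccc3c(-c4cncnc4)c(O)ccc3c2)c1`: "not determined" (no result reported) in an in vitro assay on Sf9 cells for binding affinity to 17-beta-hydroxysteroid dehydrogenase type 2 (Homo sapiens), read by scintillation counting, with a stated time of 10 min, tested at 100 nM; a higher number here means a stronger effect of the compound at the concentration tested, a lower number a weaker effect.
Compound 2 `Oc1cccc(-c2ccc3c(-c4ccc5[nH]ccc5c4)c(O)ccc3c2)c1`: "not determined" (no result reported).
Compound 3 `O=C(O)c1cccc(-c2c(O)ccc3cc(-c4cccc(O)c4)ccc23)c1`: < 10%, which is a limit of the assay and not a number.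

Compound 3 thus stands with only a limit to its name, as shown by the limit of < 10% in this assay, at which 1 of the 3 values shown sits, while compound 1 and compound 2 have no result at all. Compound 4 `O=C(O)CCC(=O)Nc1cccc(-c2c(O)ccc3cc(-c4cccc(O)c4)ccc23)c1` differs from compound 3 in one place: ((2-carboxyethyl)carbonyl)amino in place of carboxy on an aromatic carbon. Within the data shown here, no step between two measured compounds is known here, so no size or direction of change can be read from the data. The expected step, a step that the limit leaves unreadable from compound 3 to compound 4, amounts to nothing beyond the scatter. Compound 4 is therefore expected to give about 8% in this assay, with a range from 0% to 25%.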

Compound 4, a percentage reported as inhibition, at one concentration (the size of the read-out at that concentration, not a potency): 24%
Compound 4: middle estimate off by 16 percentage points, on the low side, within the range that was stated.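

In this assay, putting ((2-carboxyethyl)carbonyl)amino in place of carboxy on this aromatic carbon gives a number at least 14 percentage points higher from compound 3 to compound 4 (beyond the scatter). Among these compounds, this is the first readable sign that the position, meta to a large group, accepts this larger group with its carboxy end carried further out, with no loss of effect at the concentration tested. The value of compound 3 is a limit and not a number, so the true size of the step stays unknown: the limit of < 10% in this assay, at which 1 of the 4 values shown sits.

As far as these compounds go, whether the gain comes from the amide link or from the chain length stays open. A plain amine or a longer chain ending in a carboxylic acid at this position could help separate the two.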